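A few compounds are considered here, and "the series" means these few. Any claim that something is new, unique, unknown or untested is made for them only; others in the source may bear on it.

Compound 1 (`CCCCC/C=C\C[C@]1(O)C=CC(=O)/C1=C\C=C\CCCC(=O)OC`) gives 7900 nM
Compound 2 (`CCCCC/C=C\C[C@@]1(O)C=C(I)C(=O)/C1=C/C=C/CCCC(=O)OC`) gives 6500 nM

Both values come from a functional assay on HT-29 cells (Homo sapiens) for cytotoxicity, read by sulforhodamine B assay, with a stated time of 72 h (on this read-out higher numbers stand for weaker inhibition and lower numbers for stronger inhibition), and are the only two available. Compound 2 stands within the scatter of compound 1, so neither can be ranked above the other. Compound 3 (`CCCCC/C=C\C[C@@]1(O)C=C(I)C(=O)/C1=C\C=C\CCCC(=O)OC`) has yet to be measured in this assay and is a close relative of compound 2 (the two compounds have the same atoms and bonds and differ only in configuration as drawn: 1 of 4 stereo elements differ; a double bond is drawn E in compound 2 and Z in compound 3). Thus a double bond is drawn E in compound 2 and Z in compound 3, while the atoms and bonds stay the same. Within the data shown here, no measured pair isolates this kind of change, so the data do not show its size. With compound 1 (7900 nM) and compound 2 (6500 nM) so close, no step beyond the scatter is expected, in either direction. The estimated step of a 1.1-fold lower number from compound 2 to compound 3 (0.03 log units; within the scatter) is therefore expected to stay small. Compound 3 is expected to give about 6000 nM (estimated range 2500 nM to 13000 nM).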

Compound 3, half-maximal inhibitory concentration: > 10000 nM
Compound 3 gave a limit, no number (the forecaster's own chance of this, stated with the estimate: 5%); middle value at least 1.6-fold (0.22 log units) from the limit.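

In this assay compound 3 gives > 10000 nM, which is a limit of the assay and not a number. Among these compounds, this is the first measured pair to isolate a change of double-bond configuration, and it gives an at least 1.5-fold higher number from compound 2 to compound 3 (0.18 log units; that floor lies within the scatter), so the change from E to Z did not produce a lower number, though the floor of the step does not clear the scatter. The true size of the step cannot be read because the measurement stops at a limit: the limit of > 10000 nM in this assay, at which 1 of the 3 values shown sits.

The compounds shown leave open whether this double bond matters as much when the iodine is replaced by bromine. They also leave open how a carboxylic acid in place of the methyl ester would read in this assay.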